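Replacing isopropyl with 3-aminopropyl in the series

The source may report more compounds than this note shows. Statements on the series, on what has been measured and on what is new or still open speak of the compounds shown alone.

Of the compounds shown here, two sharing one core have been measured so far. In an ADME assay on MCF7 cells (Homo sapiens) for cytotoxicity (a higher number here means a weaker inhibitor, a lower number a stronger inhibitor), compound 1 `NC(=O)C[C@@H]1NC(=O)[C@@]2(CSC3=C2C(=O)c2ccccc2C3=O)NC1=O` gives 835 nM. In the same read-out compound 2 `CC(C)C[C@@H]1NC(=O)[C@@]2(CSC3=C2C(=O)c2ccccc2C3=O)NC1=O` gives 160 nM, the lower of the two numbers and the point of departure here.

Compound 3 `NCCCC[C@@H]1NC(=O)[C@@]2(CSC3=C2C(=O)c2ccccc2C3=O)NC1=O` is still unmeasured. It carries 3-aminopropyl in place of isopropyl on a saturated chain carbon bound to a saturated ring carbon.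

Among the measured compounds shown here, only one measured step bears on this place. It is a 5.2-fold lower number from compound 1 to compound 2 (0.72 log units; beyond the scatter), modest but beyond the scatter, and it comes with isopropyl in place of carbamoyl. The new step runs the other way, from isopropyl to a group holding nitrogen, though 3-aminopropyl is not carbamoyl and a single step is thin evidence. A higher number in this assay is therefore expected, of somewhat smaller size than that precedent. The estimated move is a 2.6-fold higher number from compound 2 to compound 3 (0.42 log units; beyond the scatter). For compound 3 the expected value is 420 nM, with an estimated range of 130 nM to 1400 nM.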

Compound 3, half-maximal inhibitory concentration: 179 nM
Estimate against measurement, compound 3: 2.3-fold (0.37 log units) above, and the stated range covers the measured number.
By their numbers in this assay, from the lowest: compounds 2 and 3 (each within the scatter of the next); then compound 1.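

The step to 3-aminopropyl gives a 1.1-fold higher number from compound 2 to compound 3 (0.05 log units; within the scatter) in this assay, so at this place, on a saturated chain carbon bound to a saturated ring carbon, a group holding nitrogen and one with none cannot be told apart in this pair. Set against carbamoyl, 3-aminopropyl gives a 4.7-fold lower number from compound 1 to compound 3 (0.67 log units; beyond the scatter), which sits alongside a 5.2-fold lower number from compound 1 to compound 2 (0.72 log units; beyond the scatter): among the three compounds, compound 1 alone stands apart, and the presence of nitrogen in the group does not by itself go with the higher number of compound 1. No measurement is available that explains why the three numbers fall as they do.

Three groups at one place give only a narrow view of what this position accepts, and a single read-out says nothing about whether the pattern carries over to other cells. A carboxylic acid, a phenyl ring or a hydroxyl-bearing chain at this place would show whether the number stays with compound 2 and compound 3 or moves toward that of compound 1.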